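Weighing a phenyl for isopropyl swap in compound 2

The source may hold more compounds than are shown below. What is called first, only, known or untested is meant among the compounds shown, and "the series" means these compounds.

Compounds measured so far:
compound 1, `CCCNC(=O)/N=C(\N)Nc1cccc(-c2csc(N)n2)c1`, 5250 nM
compound 2, `Cc1nc(N)sc1CCCN/C(N)=N/C(=O)NC(c1ccccc1)C(C)C`, 35.5 nM
compound 3, `CCCCCCNC(=O)/N=C(\N)Nc1cccc(-c2csc(N)n2)c1`, 692 nM

In an assay on membranes from Sf9 cells for displacement of a labelled ligand from histamine H2 receptor (Homo sapiens), read by scintillation counting, with a stated time of 60 min (a higher number here means a weaker inhibitor, a lower number a stronger inhibitor), compound 2 gives the lowest of the three numbers. Its nearest neighbour is compound 3, which stands well beyond the scatter above it, and compound 1 lies further still. Within the data shown here, the only step measured within one core is a 7.6-fold lower number from compound 1 to compound 3 (0.88 log units; beyond the scatter), which concerns a saturated chain on a different core and therefore bears only loosely on the present question.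

Compound 4, `Cc1nc(N)sc1CCCN/C(N)=N/C(=O)NC(c1ccccc1)c1ccccc1`, is the next compound to be measured. It differs from compound 2 in one place: phenyl in place of isopropyl on a saturated chain carbon bound to an amide-type nitrogen and an aromatic carbon. Among the measured compounds shown here, no measured pair describes this exchange, so the expectation rests on compound 2 alone and on the general observation that larger substituents on the urea side gave the lower numbers in the pair of compound 1 and compound 3. Compound 4 is therefore expected to stay close to compound 2, with a step of a 1.2-fold lower number from compound 2 to compound 4 (0.07 log units; within the scatter) in this assay. The estimate for compound 4 is 30 nM, with a range from 8 nM to 120 nM.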

Compound 4, inhibition constant: 43.7 nM
Estimate against measurement, compound 4: 1.5-fold (0.16 log units) below; the range from low to high includes it.
By their numbers in this assay, from the lowest: compounds 2 and 4 (each within the scatter of the next); then compound 3; then compound 1.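

In this assay the exchange of isopropyl for phenyl, on a saturated chain carbon bound to an amide-type nitrogen and an aromatic carbon, gives a 1.2-fold higher number from compound 2 to compound 4 (0.09 log units; within the scatter) and so leaves the two compounds indistinguishable. Among these compounds, the only earlier step, a 7.6-fold lower number from compound 1 to compound 3 (0.88 log units; beyond the scatter) on a different core, concerned a saturated chain and said nothing about this position, whereas this pair shows that going from 3 heavy atoms to 6 heavy atoms here, with one six-membered aromatic ring of carbon only entering, does not move the number beyond the scatter. No measurement among those shown offers an explanation for this result.

Going by these compounds, it remains open whether this position would hold its number with a much smaller group such as methyl, or with a phenyl carrying an amine or a carboxylic acid. On these data alone, it also remains open whether the same exchange of isopropyl for phenyl would read alike on the core of compound 1, or with a longer chain in place of the isopropyl.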